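A new group on the shared core

The source may hold more compounds than are shown below. What is called first, only, known or untested is meant among the compounds shown, and "the series" means these compounds.

In an ADME assay on microsomes from liver (Homo sapiens) for metabolic stability, read by LC-MS, using NADPH, with stated times of 5 min and 30 min, tested at 1 uM (a higher number here means faster removal of the compound, a lower number slower removal), compound 1 `Fc1ccc2c(c1CNc1ncc(Oc3ccccc3)c3nncn13)CCO2` gives 18 mL.min-1.g-1. Compound 2 `O=C(Nc1cnc(NCc2c(F)ccc3c2CCO3)n2cnnc12)c1cccnc1` gives < 3 mL.min-1.g-1, which is a limit of the assay and not a number. Compound 3 `O=C1CCCN1c1cnc(NCc2c(F)ccc3c2CCO3)n2cnnc12` differs from compound 2 in one place: 2-oxopyrrolidin-1-yl in place of ((pyridin-3-yl)carbonyl)amino on an aromatic carbon. There, 2-oxopyrrolidin-1-yl stands in place of ((pyridin-3-yl)carbonyl)amino on an aromatic carbon. Within the data shown here, the one measured step at this place is an at least 6.0-fold lower number from compound 1 to compound 2 (0.77 log units; beyond the scatter), and its size is open-ended, as the limit of < 3 mL.min-1.g-1 in this assay, at which 1 of the 2 values shown sits, shows. It gives no direct measure for the group that enters in compound 3. The rest of the structure is shared with compound 2, so only a small rise in this assay is expected, not clearly beyond the scatter. The expected step is an at least 1.6-fold higher number from compound 2 to compound 3 (0.22 log units; that floor lies within the scatter). For compound 3 the estimated value is 5 mL.min-1.g-1, with an expected range from 3 mL.min-1.g-1 to 12 mL.min-1.g-1.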

Compound 3, intrinsic clearance in microsomes: < 3 mL.min-1.g-1
Compound 3: only a limit was reported (the forecaster's own chance of this, stated with the estimate: 35%); middle value at least 1.6-fold (0.22 log units) from the limit.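

In this assay compound 3 gives < 3 mL.min-1.g-1, which is a limit of the assay and not a number. A second group at this position, 2-oxopyrrolidin-1-yl, therefore also separates from phenoxy, with an at least 6.0-fold lower number from compound 1 to compound 3 (0.77 log units; beyond the scatter), and this low reading holds without the pyridin-3-yl ring or the hydrogen-bond donor of ((pyridin-3-yl)carbonyl)amino. The step between compound 2 and compound 3 cannot be read, and the comparison of these two groups ends at the floor of the assay: the limit of < 3 mL.min-1.g-1 in this assay, at which 2 of the 3 values shown sit.

Which of the two groups is removed more slowly therefore stays open. Also open, on these data alone, is how a simple amine or a methoxy group on this aromatic carbon would read in this assay, and whether it would stay as low as compound 2 and compound 3 or come closer to compound 1.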